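The source may report more compounds than this note shows. Statements on the series, on what has been measured and on what is new or still open speak of the compounds shown alone.

- compound 1 `O=C(O)CCN1Cc2ccc(NC(=O)CCCC3CCNCC3)cc2C1=O`: 5900 nM
- compound 2 `O=C(O)CCN1Cc2ccc(NC(=O)c3ccc(C4CCNCC4)cc3)cc2C1=O`: 9600 nM
- compound 3 `O=C(O)CCN1Cc2ccc(NC(=O)c3ccc4c(c3)CNCC4)cc2C1=O`: 1100 nM

In a functional assay on a cell-free system (Platelet, plasma, Homo sapiens) for inhibition (on this read-out lower numbers stand for stronger inhibition and higher numbers for weaker inhibition), compound 1 lies within the scatter of compound 2, while compound 3 gives a number lower than compound 1 by more than the scatter.

The next compound, compound 4 `CC(CC(=O)O)N1Cc2ccc(NC(=O)CCCC3CCNCC3)cc2C1=O`, carries methyl in place of hydrogen on a saturated chain carbon bound to an amide-type nitrogen in a ring and a saturated chain carbon, turning 2-carboxyethyl into 1-(carboxymethyl)ethyl (methyl in place of hydrogen on a saturated chain carbon bound to an amide-type nitrogen in a ring and a saturated chain carbon).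

For the measured compounds named here, no measured pair differs in one place, so the expectation rests on the structural change alone, and the direction stays uncertain. The expected step of a 1.3-fold lower number from compound 1 to compound 4 (0.12 log units; within the scatter) does not go beyond the scatter. The estimated value for compound 4 is 4500 nM, with an expected range of 1500 nM to 14000 nM.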

Compound 4, half-maximal inhibitory concentration: 5400 nM
Estimate against measurement, compound 4: 1.2-fold (0.08 log units) below; low and high end bracket the measured number.
By their numbers in this assay, from the lowest: compound 3; then compounds 4, 1 and 2 (each within the scatter of the next).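

In this assay, methyl in place of hydrogen on a saturated chain carbon bound to an amide-type nitrogen in a ring and a saturated chain carbon gives a 1.1-fold lower number from compound 1 to compound 4 (0.04 log units; within the scatter). This first single-place comparison in the series shows that, on the core of compound 1, turning 2-carboxyethyl into 1-(carboxymethyl)ethyl leaves the number within the scatter. Nothing available explains this result.

Still open, as far as these compounds go, is whether a larger group on this carbon, such as ethyl or phenyl, or the same methyl on compound 3, would also stay within the scatter.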